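This account rests on a few compounds, and the source may have more. Where it says the series, first, only, none or still open, it means among the compounds named here.

Compound 3 `CC(C)c1nc(C(=O)NC[C@@H]2[C@H]3CN(CC4CCC4)C[C@@H]23)c2ccccn12`: 13.2 nM
Compound 1 `CC(C)c1nc(C(=O)NCC2(O)CCN(CC3CCOCC3)CC2)c2ccccn12`: 56.7 nM
Compound 2 `CC(C)c1nc(-c2nnc(C3CCN(C(C)C)CC3)o2)c2ccccn12`: 500 nM

These three compounds were tested in a functional assay on CHO cells for agonist activity at 5-hydroxytryptamine receptor 4 (Homo sapiens), read by a luciferase reporter and cAMP accumulation, with a stated time of 4 h; a lower number here means that less compound is needed, a higher number that more compound is needed for the effect. Compound 3 gives the lowest number of the three: compound 1 sits above it by a gap beyond the usual scatter, and compound 2 sits higher still, also beyond the scatter. Compound 4 `COC(=O)N1CCC(N2C[C@@H]3[C@@H](CNC(=O)c4nc(C(C)C)n5ccccc45)[C@@H]3C2)CC1` has not yet been measured. It differs from compound 3 in one place: 1-(methoxycarbonyl)piperidin-4-yl in place of cyclobutylmethyl on an amine nitrogen in a ring. Among the measured compounds shown here, no measured pair among the three shows this kind of exchange, so its effect can only be judged from the spread of the known values, which all share the same core and differ in the amine-bearing part and what sits on it. With compound 3 standing at 13.2 nM, the exchange is expected to move the number only modestly upward, not far beyond the scatter. The step from compound 3 to compound 4 is expected to be a 2.3-fold higher number from compound 3 to compound 4 (0.36 log units; beyond the scatter). Compound 4 is therefore estimated at 30 nM, with a plausible range from 8 nM to 120 nM.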

Compound 4, half-maximal effective concentration: 9.7 nM
For compound 4 the middle estimate is 3.1-fold (0.49 log units) above the measured one; the range from low to high includes it.
By their numbers in this assay, from the lowest: compounds 4 and 3 (each within the scatter of the next); then compound 1; then compound 2.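

In this assay, putting 1-(methoxycarbonyl)piperidin-4-yl in place of cyclobutylmethyl on this amine nitrogen in a ring gives a 1.4-fold lower number from compound 3 to compound 4 (0.13 log units; within the scatter). Among the compounds shown here, at this position, then, a group of 10 heavy atoms with 2 hydrogen-bond acceptors can replace one of 5 heavy atoms with no acceptors and leave the number within the usual scatter, something the earlier compounds, which differ in more than one place, could not show. Nothing measured here explains why the two compounds read alike.

On these data alone, it remains open whether the methoxycarbonyl group contributes to this result, or whether the piperidine ring alone would read the same. As far as these compounds go, how a smaller group such as methyl, or one carrying a carboxylic acid, would read on this same nitrogen is also open.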